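The source may hold more compounds than are shown below. What is called first, only, known or untested is meant among the compounds shown, and "the series" means these compounds.

Measured so far:
- compound 1 `CCC(c1nc(SC(C)C)[nH]c(=O)c1C)c1c(F)cccc1F` at > 30000 nM (a limit)
- compound 2 `CCC(C)Sc1nc(C(CC)c2c(F)cccc2F)c(C)c(=O)[nH]1` at > 3000 nM (a limit)

In an ADME assay on MT4 cells (Homo sapiens) for activation, read by MTT assay (on this read-out higher numbers stand for lower toxicity in this test and lower numbers for higher toxicity in this test), compound 2 stands only at the limit > 3000 nM and has no number. Compound 3 `CCC(c1nc(SC2CCCC2)[nH]c(=O)c1C)c1c(F)cccc1F` brings cyclopentyl in place of sec-butyl on a sulfur. The measured step that the two limits leave unreadable from compound 1 to compound 2 concerns the same sulfur substituent but gives no size and no direction to carry over. The expectation rests only on compound 1 and compound 2 both reporting limits, and a further limit is the likeliest report. The estimate means a step that the limit leaves unreadable from compound 2 to compound 3 as an expected step, set against a limit only. Compound 3 is estimated at 20000 nM with 4000 nM to 100000 nM as the expected range.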

Compound 3, half-maximal cytotoxic concentration: 30000 nM
Beside the measured number, compound 3's estimate is 1.5-fold (0.18 log units) below it; the measured number falls inside the stated range.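

In this assay, among these compounds, compound 3, with cyclopentyl on the sulfur, gives 30000 nM, the first value that is a number and not a limit. Cyclopentyl in place of isopropyl on a sulfur gives a number no higher from compound 1 to compound 3 (the limit leaves the size open). On these data alone, the step into compound 3 from compound 2 cannot be read, so the size of the change from sec-butyl to cyclopentyl stays unknown. The ring therefore gives this position its only numerical anchor so far. As far as these compounds go, how a cyclohexyl, a benzyl or an aminoethyl group on this sulfur would read in this assay remains open.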